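Amine substituent change on the shared core

The source may hold more compounds than are shown below. What is called first, only, known or untested is meant among the compounds shown, and "the series" means these compounds.

Measured so far:
compound 1, `CCCN(CC1CC1)c1nc(C)nc2c(-c3ccc(OC)cc3C)c(C)nn12`: 1.96 nM in an assay on cell membranes for displacement of a labelled ligand from corticotropin-releasing factor receptor 1 (Rattus norvegicus); on this read-out lower numbers stand for stronger inhibition and higher numbers for weaker inhibition
compound 2, `CCC(CC)Nc1nc(C)nc2c(-c3c(C)cc(OC)cc3OC)c(C)nn12`: 5 nM in this assay

Compound 1 holds the lowest of the two numbers; compound 2 gives a higher number, a gap beyond the usual scatter. Compound 3, `CCCN(CCC#N)c1nc(C)nc2c(-c3ccc(OC)cc3C)c(C)nn12`, is not yet measured. It differs from compound 1 in one place: cyanomethyl in place of cyclopropyl on a saturated chain carbon bound to a nitrogen on an aromatic ring. Within the data shown here, no step between measured compounds maps this change; the expectation rests on compound 1 and the change itself. In this assay a small shift toward a higher number is expected, close to the scatter, giving a 2.0-fold higher number from compound 1 to compound 3 (0.31 log units; beyond the scatter). Compound 3 is accordingly estimated at 4 nM, within 1.5 nM to 12 nM.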

Compound 3, half-maximal inhibitory concentration: 2.16 nM
For compound 3 the middle estimate is 1.9-fold (0.27 log units) above the measured one; the range from low to high includes it.
By their numbers in this assay, from the lowest: compounds 1 and 3 (each within the scatter of the next); then compound 2.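

In this assay the cyanomethyl replacement for cyclopropyl, on a saturated chain carbon bound to a nitrogen on an aromatic ring, gives a step within the scatter (a 1.1-fold higher number from compound 1 to compound 3 (0.04 log units; within the scatter)). This place on the shared core therefore accepts a 2-cyanoethyl chain, with no ring and a nitrile end, as well as cyclopropylmethyl. Nothing available explains this result. Going by these compounds, whether a carboxylic acid or a primary amine at the end of this chain would also keep the number stays open, as does a longer chain ending in a nitrile.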